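The source may hold more compounds than are shown below. What is called first, only, known or untested is meant among the compounds shown, and "the series" means these compounds.

Measured compounds:
Compound 1, `Oc1ccc(O)c(-c2cc(-c3ccc(Cl)cc3)nn2-c2ccccc2)c1`, gives 41100 nM in a functional assay on cells (Cancer cell lines, Homo sapiens) for cytotoxicity, read by sulforhodamine B assay, with a stated time of 48 h; a higher number here means a weaker inhibitor of growth, a lower number a stronger inhibitor of growth.
Compound 2, `CC(=O)NS(=O)(=O)c1ccc(-n2nc(-c3ccccc3)cc2-c2cc(O)ccc2O)cc1`, gives 100000 nM in this assay.
Compound 3, `O=C1C=CC(=O)C(c2cc(-c3ccc(Cl)cc3)nn2-c2ccccc2)=C1`, gives 69300 nM in this assay.

Compound 2 stands at the highest of the three numbers; the difference between its core and that of compound 1 is not broken down here. Compound 2 and compound 3 lie within the scatter of each other, while compound 1 sits a step beyond the scatter below compound 2.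

The change from compound 1 to compound 3 is a group of 8 heavy atoms (6 carbon, 2 oxygen; one six-membered non-aromatic ring of carbon only) in place of a group of 8 heavy atoms (6 carbon, 2 oxygen; one six-membered aromatic ring of carbon only), on an aromatic carbon, and it produced a 1.7-fold higher number from compound 1 to compound 3 (0.23 log units; within the scatter). The unmeasured compound 4, `CC(=O)NS(=O)(=O)c1ccc(-n2nc(-c3ccccc3)cc2C2=CC(=O)C=CC2=O)cc1`, carries the same kind of change relative to compound 2: a group of 8 heavy atoms (6 carbon, 2 oxygen; one six-membered non-aromatic ring of carbon only) in place of a group of 8 heavy atoms (6 carbon, 2 oxygen; one six-membered aromatic ring of carbon only), on an aromatic carbon. The surroundings of the place differ in that, on the core of compound 1, the site is next to the ring atom that bears a phenyl group and two ring bonds from the ring atom that bears a 4-chlorophenyl group, whereas on the core of compound 2 it is next to the ring atom that bears a large group and two ring bonds from the ring atom that bears a phenyl group.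

Since the single measured instance of this change was within the scatter, compound 4 is expected to land near compound 2; the estimate is 150000 nM, which means an expected step of a 1.5-fold higher number from compound 2 to compound 4 (0.18 log units; within the scatter), resting on compound 3 having shown a 1.7-fold higher number from compound 1 to compound 3 (0.23 log units; within the scatter). Compound 4 is estimated to fall between 70000 nM and 320000 nM in this assay.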

Compound 4, concentration for total growth inhibition: 100000 nM
Beside the measured number, compound 4's estimate is 1.5-fold (0.18 log units) above it, within the range that was stated.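

In this assay, the non-aromatic ring taking the place of the 2,5-dihydroxyphenyl group gave no change at the digits printed from compound 2 to compound 4 (within the scatter). Set beside the earlier instance of the same exchange on the other core, the two steps do not differ by more than repeated measurements of this kind would: the same change on two cores in this assay, a 1.7-fold higher number (0.23 log units; within the scatter) from compound 1 to compound 3 and no change at the digits printed (within the scatter) from compound 2 to compound 4, 1.7-fold (0.23 log units) apart, within the scatter of two such steps. This shows that, in these two pairs, the exchange carries from one core to the other with no difference that can be told from the scatter, but neither step lies beyond the scatter, so the agreement is between two results that each show no clear effect, and two pairs cannot show that the exchange would behave alike on any further core in the series.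

What the compounds shown leave open is whether the exchange would still read the same on a core where a strong effect of the group could be seen, for example one carrying a carboxylic acid or an amine in place of the 4-chlorophenyl group. They also leave open how a ring with only one hydroxyl, or with methoxy groups in place of the hydroxyls, would compare with the 2,5-dihydroxyphenyl group on either core.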